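Ethynyl in place of bromo: what to expect

The source may report more compounds than this note shows. Statements on the series, on what has been measured and on what is new or still open speak of the compounds shown alone.

For the measured compounds named here, compound 2 `Cc1ccc([N+](=O)[O-])cc1S(=O)(=O)N(C)/N=C/c1cnn2ccc(Br)cc12` is the only compound here with an actual number: in an assay on isolated protein for inhibition of phosphatidylinositol 4,5-bisphosphate 3-kinase catalytic subunit beta isoform (Homo sapiens), read by 33P incorporation, with a stated time of 60 min (on this read-out lower numbers stand for stronger inhibition and higher numbers for weaker inhibition), compound 2 gives 230 nM. Compound 1 `Cc1ccc([N+](=O)[O-])cc1S(=O)(=O)N(C)/N=C/c1cnn2c(C)cccc12` reaches only a limit, giving > 1000 nM in this assay; this is the limit of > 1000 nM in this assay, at which 1 of the 2 values shown sits. Compound 3 `C#Cc1ccn2ncc(/C=N/N(C)S(=O)(=O)c3cc([N+](=O)[O-])ccc3C)c2c1` differs from compound 2 by ethynyl in place of bromo on an aromatic carbon. No measured step of this kind stands among these compounds, so the change is expected to stay within the usual scatter, with no clear direction. Compound 3 is therefore estimated at 250 nM in this assay, between 90 nM and 700 nM, an expected step of a 1.1-fold higher number from compound 2 to compound 3 (0.04 log units; within the scatter).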

Compound 3, half-maximal inhibitory concentration: 30 nM
Compound 3: the middle estimate sits 8.3-fold (0.92 log units) above what was measured, outside the stated range (below it).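

Ethynyl in place of bromo gives a 7.7-fold lower number from compound 2 to compound 3 (0.88 log units; beyond the scatter) in this assay and so shows that this position, opposite the ring nitrogen, responds to the group it carries. The step goes beyond the scatter, although neither group has a hydrogen-bond donor or acceptor. Nothing measured here accounts for its size.

A single step at one position cannot show whether the triple bond itself matters. A nitrile, a longer alkyne chain or an amine at the same place would test how far the gain extends.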